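Adding one methoxy to compound 2

This account rests on a few compounds, and the source may have more. Where it says the series, first, only, none or still open, it means among the compounds named here.

Measured so far in a functional assay on SEM cells (Homo sapiens) for inhibition, read by MTT assay, with a stated time of 72 h (on this read-out higher numbers stand for weaker inhibition and lower numbers for stronger inhibition), for these compounds:
- compound 1 (`COc1cccc(/C=C/C(=O)Nc2cc(OC)c(OC)c(OC)c2)c1`) reads 18200 nM
- compound 2 (`C=C(Br)C(=O)Nc1cccc(/C=C/C(=O)Nc2ccc(OC)c(OC)c2)c1`) reads 3 nM

Compound 2 has the lower number of the two, and its gap to compound 1 lies well beyond the scatter. These two compounds differ in more than one place, so their values isolate no single change.

Compound 3 (`C=C(Br)C(=O)Nc1cccc(/C=C/C(=O)Nc2cc(OC)c(OC)c(OC)c2)c1`) differs from compound 2 by methoxy in place of hydrogen on an aromatic carbon and nothing else. For the measured compounds named here, no measured step covers this change. Going by the values given here, compound 3 shares its methoxy-bearing end with compound 1, but that pair differs elsewhere, so it sets no size for the step. Only a small move toward weaker inhibition in this assay is expected, possibly none beyond the scatter. The expected change is a 2.0-fold higher number from compound 2 to compound 3 (0.30 log units; within the scatter) on this reasoning. For compound 3 the estimated value is 6 nM in this read-out, with an expected range from 1.5 nM to 30 nM on repeat measurement.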

Compound 3, half-maximal inhibitory concentration: 18 nM
Compound 3: the middle estimate sits 3.0-fold (0.48 log units) below what was measured; the range from low to high includes it.
By their numbers in this assay, from the lowest: compound 2; then compound 3; then compound 1.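

In this assay, methoxy in place of hydrogen on an aromatic carbon, ortho to a methoxy group and meta to a large group, gives a 6.0-fold higher number from compound 2 to compound 3 (0.78 log units; beyond the scatter) and so is not a silent change at this position, though compound 3 still reads far lower than compound 1, with compound 3 at 18 nM and compound 1 at 18200 nM. The first single-change measure at the other end of the series is ((1-bromoethenyl)carbonyl)amino in place of methoxy on an aromatic carbon, which gives a 1000-fold lower number from compound 1 to compound 3 (3.00 log units; beyond the scatter) and so far outweighs the methoxy step. Nothing measured on these compounds speaks to the origin of either step.

From the compounds shown here alone, whether a hydroxyl or an ethoxy at the same aromatic carbon would read closer to compound 2 or to compound 3 remains open. Also open, going by these compounds, is how much of the large step survives with a plain amine in place of ((1-bromoethenyl)carbonyl)amino.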